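Swapping neopentyl for (tert-butyl)amino on compound 3

This account rests on a few compounds, and the source may have more. Where it says the series, first, only, none or still open, it means among the compounds named here.

Of the compounds shown here, three with a shared core have been measured in a physicochemical assay for solubility; on this read-out lower numbers stand for lower solubility and higher numbers for higher solubility. Compound 1 `O=C(Cn1ccnc1)N1CCC(NS(=O)(=O)c2cc(S(=O)(=O)c3ccccc3)ccc2C(F)(F)F)CC1` gives 100000 nM. Compound 2 `CC(C)(C)OC(=O)N1CCC[C@@H]1C(=O)N1CCC(NS(=O)(=O)c2cc(S(=O)(=O)c3ccccc3)ccc2C(F)(F)F)CC1` gives 25000 nM. Compound 3 `CC(C)(C)CC(=O)N1CCC[C@H]1C(=O)N1CCC(NS(=O)(=O)c2cc(S(=O)(=O)c3ccccc3)ccc2C(F)(F)F)CC1` gives 25000 nM, level with compound 2, and together they hold the lowest of the three numbers.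

Compound 4 `CC(C)(C)NC(=O)N1CCC[C@H]1C(=O)N1CCC(NS(=O)(=O)c2cc(S(=O)(=O)c3ccccc3)ccc2C(F)(F)F)CC1` differs from compound 3 by having (tert-butyl)amino in place of neopentyl on a carbonyl carbon. Among the measured compounds shown here, no measured compound carries this (tert-butyl)amino group, so the evidence is indirect. The closest measured change is no change at the digits printed from compound 2 to compound 3 (within the scatter). The two larger steps, a 4.0-fold lower number from compound 1 to compound 2 (0.60 log units; beyond the scatter) and a 4.0-fold lower number from compound 1 to compound 3 (0.60 log units; beyond the scatter), both remove (1H-imidazol-1-yl)methyl, a group that compound 4 does not have, and so they bear less on this swap.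

Following the small step from compound 2, no change beyond the scatter is expected in this assay. The estimated step is a 1.2-fold higher number from compound 3 to compound 4 (0.08 log units; within the scatter). Compound 4 is expected to read about 30000 nM, within a range of 12000 nM to 75000 nM.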

Compound 4, solubility: 50000 nM
The estimate for compound 4 lay 1.7-fold (0.22 log units) below the measured number; measured number inside the range.
By their numbers in this assay, from the lowest: compounds 2, 3, 4 and 1 (each within the scatter of the next, the first and the last beyond it).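

On this carbonyl carbon, (tert-butyl)amino brings one hydrogen-bond donor and puts a nitrogen where neopentyl has a carbon, with the heavy-atom count unchanged, yet in this assay this exchange stays inside the scatter (a 2.0-fold higher number from compound 3 to compound 4 (0.30 log units; within the scatter)). Compound 4 also cannot be separated from either of the compounds that are set apart beyond the scatter, as its steps from the tert-butoxycarbonyl compound (a 2.0-fold higher number from compound 2 to compound 4 (0.30 log units; within the scatter)) and from the imidazole-bearing compound (a 2.0-fold lower number from compound 1 to compound 4 (0.30 log units; within the scatter)) both remain within the scatter. Nothing measured here explains the reading of compound 4.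

Going by these compounds, whether any group on this carbonyl carbon can move the number beyond the scatter stays open. A primary amine, a carboxylic acid or a longer ether chain in this place would test that.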